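Removing the Nitrile from the Benzyl Group of Compound 2

The compounds below may be only part of what the source reports. "The series", "measured", "known", "first", "only" and "open" are said of these compounds alone.

The measured compounds and their values in a functional assay (B cells) with Mus musculus as the target; on this read-out higher numbers stand for an effect only at larger amounts of compound and lower numbers for an effect already at smaller amounts:
compound 1, `Nc1nc(O)c2c(n1)n(C1OC(CO)[C@@H](O)[C@H]1O)c(=O)n2CC(O)CO`, gives 45 uM
compound 2, `N#Cc1cccc(Cn2c(=O)n(C3OC(CO)[C@@H](O)[C@H]3O)c3nc(N)nc(O)c32)c1`, gives 3 uM
compound 3, `C=CCn1c(=S)n(C2OC(COC(C)=O)[C@H]3OC(C)(C)O[C@@H]23)c2nc(N)nc(O)c21`, gives 50 uM

Compound 2 stands at the lowest number of the three in this assay, and its steps to both compound 1 and compound 3 lie beyond the scatter, so it is the most potent compound in the set. Compound 4, `Nc1nc(O)c2c(n1)n(C1OC(CO)[C@@H](O)[C@H]1O)c(=O)n2Cc1ccccc1`, differs from compound 2 in one place: hydrogen in place of cyano on an aromatic carbon. Cut one bond further out, the change reads 3-cyanophenyl to phenyl, or 3-cyanobenzyl to benzyl.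

For the measured compounds named here, only one measured step bears on this change. From compound 1 to compound 2 the number fell sharply, a 15-fold lower number from compound 1 to compound 2 (1.18 log units; beyond the scatter), when 3-cyanophenyl replaced 1,2-dihydroxyethyl on the saturated chain carbon bound to the aromatic nitrogen. That step shows that the 3-cyanobenzyl group is far better here than the diol chain, but it does not separate the part of the gain carried by the phenyl ring from the part carried by the cyano group. Compound 3 carries a different substituent on this nitrogen and does not speak to the cyano group.

Because the step of a 15-fold lower number from compound 1 to compound 2 (1.18 log units; beyond the scatter) is large, compound 4 is expected to keep most of that gain when the phenyl ring stays and only the cyano group leaves, with a moderate rise in number, a 2.7-fold higher number from compound 2 to compound 4 (0.43 log units; beyond the scatter). Compound 4 is therefore estimated at 8 uM, within a range from 3 uM to 25 uM.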

Compound 4, concentration for half-maximal effect: 6 uM
For compound 4 the middle estimate is 1.3-fold (0.12 log units) above the measured one, within the range that was stated.
By their numbers in this assay, from the lowest: compounds 2 and 4 (each within the scatter of the next); then compounds 1 and 3 (each within the scatter of the next).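

In this assay there is a 2.0-fold higher number from compound 2 to compound 4 (0.30 log units; within the scatter) and so, on this six-membered aromatic ring of carbon only, the nitrile can give way to hydrogen without a difference that stands out from repeated measurement. For the compounds shown here, this separates what the earlier compounds left joined: with no cyano group present there is still a 7.5-fold lower number from compound 1 to compound 4 (0.88 log units; beyond the scatter) and that step lies beyond the scatter, so the phenyl group on the saturated chain carbon bound to the aromatic nitrogen is enough for a clear difference from the 1,2-dihydroxyethyl group, and the cyano group is not required for it. No independent measurement is available to explain either step.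

The compounds shown do not tell whether an amine or a carboxylic acid on this aromatic carbon would stay within the scatter of hydrogen and cyano, or would move the number clearly in either direction. They also leave open whether a longer chain, such as phenethyl in place of benzyl on the aromatic nitrogen, would keep the number of the benzyl compounds.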